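Cytotoxicity of piperidine-carboxanilides: a triazole for a pyridinyloxy

The source may hold more compounds than are shown below. What is called first, only, known or untested is meant among the compounds shown, and "the series" means these compounds.

Measured so far:
Compound 1, `O=C(Nc1cccc(Oc2ccccn2)c1)C1CCCN(C(=O)c2cc(C(F)(F)F)cc(C(F)(F)F)c2)C1`, 0%
Compound 2, `O=C(Nc1ccc(Cl)cc1)C1CCCN(C(=O)c2cccc([N+](=O)[O-])c2)C1`, 0%
Compound 3, `COc1cccc(C(=O)N2CCCC(C(=O)Nc3ccc(Cl)cc3)C2)c1`, 0%

In an ADME assay on PC-3 cells (Homo sapiens) for cytotoxicity, read by WST assay, tested at 100 uM (on this read-out lower numbers stand for less inhibition and higher numbers for more inhibition at the one concentration tested (going by the name of the read-out)), compound 1 gives 0%. Compound 2 gives 0% and compound 3 gives 0%, so all three stand level at the digits shown, each within the scatter of the others. Going by the values given here, the only step between two measured compounds that differ in one place is no change at the digits printed from compound 2 to compound 3 (within the scatter), which swaps methoxy in place of nitro on an aromatic carbon and leaves the read-out where it was.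

Compound 4, `Cn1cnnc1-c1cccc(NC(=O)C2CCCN(C(=O)c3cc(C(F)(F)F)cc(C(F)(F)F)c3)C2)c1`, has not yet been measured. It differs from compound 1 by 4-methyl-4H-1,2,4-triazol-3-yl in place of (pyridin-2-yl)oxy on an aromatic carbon, the new group sitting on an aromatic carbon of a six-membered aromatic ring of carbon only, meta to a large group. Among the compounds with values here, no measured step touches this position or this kind of exchange; the one step available, from a nitro to a methoxy elsewhere on the shared core, moved nothing. With the numbers of all measured compounds level at the single concentration tested, the step of no change at the digits printed from compound 1 to compound 4 (within the scatter) is expected to stay within the scatter. Compound 4 is therefore estimated at 0%, with a range from -5% to 12%.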

Compound 4, a percentage reported as inhibition, at one concentration (the size of the read-out at that concentration, not a potency): 0%
Compound 4: middle estimate and measured number agree at the digits printed, within the range that was stated.
By their numbers in this assay, from the lowest: compounds 1, 2, 3 and 4 (each within the scatter of the next).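

In this assay, going by these compounds alone, the exchange of (pyridin-2-yl)oxy for 4-methyl-4H-1,2,4-triazol-3-yl on an aromatic carbon, meta to a large group, gives no change at the digits printed from compound 1 to compound 4 (within the scatter), and this is the first step that can be read at this position. The earlier step concerned a different part of the shared core, whereas this one shows that, at the single concentration tested, one six-membered aromatic ring with 1 hetero atom can give way at this place to one five-membered aromatic ring with 3 hetero atoms without moving the read-out beyond the scatter. No measured property of either group bears on this outcome, so the result stands without an explanation.

With all four compounds level, the read-out gives no order among them and does not show which parts of the shared core, if any, can shift it. It also leaves open whether a primary amine, a carboxylic acid or a longer chain such as an n-butoxy group on this same aromatic carbon would stay level with compound 1 and compound 4.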